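This account rests on a few compounds, and the source may have more. Where it says the series, first, only, none or still open, it means among the compounds named here.

Measured so far:
- Compound 1, `O=C(Nc1ccccc1C(F)(F)F)c1ccc2cccc(O)c2n1`. In an ADME assay on THP-1 cells (Homo sapiens) for cytotoxicity, read by WST assay, with a stated time of 24 h (a higher number here means a weaker inhibitor, a lower number a stronger inhibitor), compound 1 gives > 30000 nM, which is a limit of the assay and not a number.
- Compound 2, `O=C(Nc1cccc(C(F)(F)F)c1)c1ccc2cccc(O)c2n1`. In this assay compound 2 gives > 30000 nM, again a limit.
- Compound 3, `O=C(Nc1ccccc1[N+](=O)[O-])c1ccc2cccc(O)c2n1`. In this assay compound 3 gives > 30000 nM, also a limit.

Compound 4, `O=C(Nc1cccc([N+](=O)[O-])c1)c1ccc2cccc(O)c2n1`, is not yet measured. The difference between the cores of compound 1 and compound 2 is not broken down here. From compound 1 to compound 3 the change is nitro in place of trifluoromethyl on an aromatic carbon, and from compound 2 to compound 4 it is nitro in place of trifluoromethyl on an aromatic carbon; the places differ, ortho to a large group in the first pair and meta to a large group in the second, so the two are the same kind of change rather than the same. The measured step is a step that the two limits leave unreadable from compound 1 to compound 3, since both ends sit at the limit of > 30000 nM in this assay, at which 3 of the 3 values shown sit.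

For the measured compounds named here, for compound 4 the expected step is a step that the limit leaves unreadable from compound 2 to compound 4, resting on (the limit of > 30000 nM in this assay, at which 3 of the 3 values shown sit), where every value of the series so far sits. Compound 4 is therefore estimated at 40000 nM, with a range from 20000 nM to 100000 nM.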

Compound 4, half-maximal inhibitory concentration: > 30000 nM
Compound 4 ended at the assay's limit (the forecaster's own chance of this, stated with the estimate: 85%); the middle value is on the limit's open side.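

In this assay compound 4 gives > 30000 nM as a limit and not a number. Compound 2 also stands at a limit, and no step can be read from compound 2 to compound 4. The compounds shown leave open whether any of the four differ in cytotoxicity, and at what concentration any would reach half-maximal inhibition.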